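The source may hold more compounds than are shown below. What is called first, only, known or untested is meant among the compounds shown, and "the series" means these compounds.

Compound 1 `O=C(c1ccccc1)c1sc(N2CCCC2)nc1Cl` and compound 2 `O=C(c1ccccc1)c1sc(N2CCCCC2)nc1Cl` share one core and differ by piperidin-1-yl in place of pyrrolidin-1-yl on an aromatic carbon. In a functional assay on PC-3 cells (Homo sapiens) for cytotoxicity, read by MTT assay, with a stated time of 72 h (a higher number here means a weaker inhibitor, a lower number a stronger inhibitor), compound 1 gives only a limit of the assay, > 100000 nM. In this assay compound 2 gives 69000 nM. That change made an at least 1.4-fold lower number from compound 1 to compound 2 (0.16 log units; that floor lies within the scatter).

Compound 3 `COC(=O)c1sc2nc(N3CCCC3)sc2c1C` rests on a different core; how the two cores differ is not broken down here. In this assay compound 3 gives only a limit, > 100000 nM. Compound 4 `COC(=O)c1sc2nc(N3CCCCC3)sc2c1C` differs from compound 3 by piperidin-1-yl in place of pyrrolidin-1-yl on an aromatic carbon. This is the same kind of change as before, though the surroundings differ: here the ring is part of a fused or bridged system of two rings, whereas in compound 1 the place lies two ring bonds from the ring atom that bears a chloro group and from the ring atom that bears a group of 8 heavy atoms.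

The step is expected to be an at least 1.2-fold lower number from compound 3 to compound 4 (0.09 log units; that floor lies within the scatter), a guess of the same small size as before, because the limit of > 100000 nM in this assay, at which 2 of the 3 values shown sit, leaves little room to read the earlier step. Compound 4 is therefore estimated at 80000 nM, likely between 30000 nM and 250000 nM.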

Compound 4, half-maximal inhibitory concentration: 93000 nM
Estimate against measurement, compound 4: 1.2-fold (0.07 log units) below; the range from low to high includes it.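

The swap of pyrrolidin-1-yl for piperidin-1-yl on the core of compound 3 gives, in this assay, an at least 1.0-fold lower number from compound 3 to compound 4 (0.03 log units; that floor lies within the scatter). Set beside the earlier case, the two cores can be compared only loosely: the same change on two cores in this assay, an at least 1.4-fold lower number (0.16 log units; that floor lies within the scatter) from compound 1 to compound 2 and an at least 1.0-fold lower number (0.03 log units; that floor lies within the scatter) from compound 3 to compound 4; the limit leaves it open whether they differ. The data therefore neither show that the change carries over from one core to the other with the same size nor show that it fails to, and much of this small set rests on a limit rather than a number: the limit of > 100000 nM in this assay, at which 2 of the 4 values shown sit.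

Still open, going by these compounds, is how other groups on that aromatic carbon would behave, such as morpholin-4-yl or an open-chain amine like diethylamino. On these data alone, it is also open whether any of them would give values well clear of the limit.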